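The source may report more compounds than this note shows. Statements on the series, on what has been measured and on what is new or still open speak of the compounds shown alone.

Measured compounds:

Compound 1, `Cn1c(-c2ccc([N+](=O)[O-])cc2)nc2cc(C(F)(F)F)ccc21`, a limit in this test of > 100000 nM.
Compound 2, `CC(=O)Nc1ccc(-c2nc3cc(C(F)(F)F)ccc3n2C)cc1`, a limit in this test of > 100000 nM.
Compound 3, `O=[N+]([O-])c1ccc(-c2nc3cc(Cl)c(Cl)cc3[nH]2)cc1`, a limit in this test of > 100000 nM.

All three were run in an ADME assay on BHK cells (Mesocricetus auratus) for cytotoxicity, read by MTT assay, with a stated time of 96 h; on this read-out higher numbers stand for lower toxicity in this test and lower numbers for higher toxicity in this test. For compound 1 the read-out is only a limit, > 100000 nM. For compound 2 the read-out is again only a limit, > 100000 nM. For compound 3 the read-out is likewise a limit, > 100000 nM.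

Compound 1 and compound 2 differ in one place, (acetamido in place of nitro on an aromatic carbon), and the step in this assay is a step that the two limits leave unreadable from compound 1 to compound 2. Its size cannot be read because of the limit of > 100000 nM in this assay, at which 3 of the 3 values shown sit, so the two limits say nothing about whether the acetamido changes toxicity on the core of compound 1.

Compound 3 carries a different core; how it differs from the core of compound 1 is not broken down here. Compound 4, `CC(=O)Nc1ccc(-c2nc3cc(Cl)c(Cl)cc3[nH]2)cc1`, is the one not yet measured. It differs from compound 3 by acetamido in place of nitro on an aromatic carbon, the same change that leads from compound 1 to compound 2, with the place described in the same words.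

For compound 4 the step that the limit leaves unreadable from compound 3 to compound 4 is expected, on the ground that the same change gave a step that the two limits leave unreadable from compound 1 to compound 2 and that compound 3 already sits at the limit of > 100000 nM in this assay, at which 3 of the 3 values shown sit. Compound 4 is therefore estimated at 150000 nM, most likely again reported only as a limit, within 80000 nM to 400000 nM.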

Compound 4, half-maximal cytotoxic concentration: > 100000 nM
Compound 4 was reported as a limit (the forecaster's own chance of this, stated with the estimate: 85%); the middle value lies beyond the limit too.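

In this assay no step can be read between compound 3 and compound 4, nor between compound 1 and compound 2, because every value shown is the same limit: the limit of > 100000 nM in this assay, at which 4 of the 4 values shown sit. The compounds shown leave open whether acetamido in place of nitro on an aromatic carbon changes toxicity in this test on either core, and at what concentration, if any, any of the four compounds harms these cells.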